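From hydroxy to propyl: an estimate for compound 4

The source may hold more compounds than are shown below. What is called first, only, known or untested is meant among the compounds shown, and "the series" means these compounds.

Three measured compounds share one core and differ only in the group on the aromatic carbon. Compound 1 `O=c1cc(Cn2cc(C3CC3)nn2)c2ccc(O)cc2o1` carries cyclopropyl; in a functional assay on HeLa cells (Homo sapiens) for inhibition, read by MTT assay, with a stated time of 72 h (on this read-out lower numbers stand for stronger inhibition and higher numbers for weaker inhibition), compound 1 reaches only the limit > 100000 nM (the limit of > 100000 nM in this assay, at which 1 of the 3 values shown sits). Compound 2 `O=c1cc(Cn2cc(CCCCl)nn2)c2ccc(O)cc2o1` carries 3-chloropropyl and gives 49600 nM. Compound 3 `O=c1cc(Cn2cc(CCCO)nn2)c2ccc(O)cc2o1` carries 3-hydroxypropyl and gives 90200 nM, the highest of the two numbers, with compound 2 nearest. Compound 4 `CCCCCCc1cn(Cc2cc(=O)oc3cc(O)ccc23)nn1` differs from compound 3 by propyl in place of hydroxy on a saturated chain carbon, three bonds along the chain from an aromatic carbon. Within the data shown here, the one measured step that bears on this change is a 1.8-fold higher number from compound 2 to compound 3 (0.26 log units; within the scatter), a step within the scatter, so compound 4 is expected to move by a 2.3-fold lower number from compound 3 to compound 4 (0.35 log units; beyond the scatter), a modest lowering at most. Compound 4 is estimated at 40000 nM, between 15000 nM and 100000 nM.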

Compound 4, half-maximal inhibitory concentration: 59000 nM
For compound 4 the middle estimate is 1.5-fold (0.17 log units) below the measured one; the range from low to high includes it.
By their numbers in this assay, from the lowest: compounds 2, 4 and 3 (each within the scatter of the next). At a limit, above all of these: compound 1.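

Hexyl in compound 4 cannot be told apart in this assay from the chains ending in hydroxy or chloro (a 1.5-fold lower number from compound 3 to compound 4 (0.18 log units; within the scatter)) and (a 1.2-fold higher number from compound 2 to compound 4 (0.08 log units; within the scatter)). Across compounds 2, 3 and 4, then, changing the end of this chain leaves the number within the scatter, even when propyl replaces hydroxy or chloro. Compound 1 gives only a limit, so the step to hexyl (an at least 1.6-fold lower number from compound 1 to compound 4 (0.22 log units; that floor lies within the scatter)) sets a floor and not a size: the limit of > 100000 nM in this assay, at which 1 of the 4 values shown sits. As far as these compounds go, whether an amine or a carboxylic acid at the chain end, or a chain longer than hexyl, would move the number beyond the scatter stays open.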